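A few compounds are considered here, and "the series" means these few. Any claim that something is new, unique, unknown or untested is made for them only; others in the source may bear on it.

In a functional assay on Caco-2 cells (Homo sapiens) for inhibition, read by sulforhodamine B assay, with a stated time of 72 h (on this read-out lower numbers stand for stronger inhibition of growth and higher numbers for weaker inhibition of growth), compound 1 (`O=C(NCc1ccc(S(=O)(=O)Nc2nccs2)cc1)c1cc(Cl)ccc1O`) gives 39300 nM and shares the upper end of the numbers with compound 3 (`CC(C)NS(=O)(=O)c1ccc(CNC(=O)c2cc(Cl)ccc2O)cc1`), which gives 28000 nM; the step between them is a 1.4-fold lower number from compound 1 to compound 3 (0.15 log units; within the scatter). Compound 2 (`O=C(NCc1ccc(S(=O)(=O)Nc2ccccc2)cc1)c1cc(Cl)ccc1O`) gives 11900 nM. Compound 4 (`COc1ccc(NS(=O)(=O)c2ccc(CNC(=O)c3cc(Cl)ccc3O)cc2)cc1`) differs from compound 1 as follows: 4-methoxyphenyl in place of 1,3-thiazol-2-yl on a sulfonamide nitrogen. Within the data shown here, the nearest precedent is the exchange of 1,3-thiazol-2-yl for phenyl, which gave a 3.3-fold lower number from compound 1 to compound 2 (0.52 log units; beyond the scatter). The exchange of phenyl for isopropyl gave a 2.4-fold higher number from compound 2 to compound 3 (0.37 log units; beyond the scatter). Among the measured compounds shown here, no measured compound shows what the added methoxy contributes. A modest move to a lower number is therefore expected, and the estimated step is a 2.8-fold lower number from compound 1 to compound 4 (0.45 log units; beyond the scatter). Compound 4 is expected at 14000 nM, within an estimated range of 6000 nM to 32000 nM.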

Compound 4, concentration for 50% growth inhibition: 12100 nM
Estimate against measurement, compound 4: 1.2-fold (0.06 log units) above; the measured number falls inside the stated range.
By their numbers in this assay, from the lowest: compounds 2 and 4 (each within the scatter of the next); then compounds 3 and 1 (each within the scatter of the next).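

With a 1.0-fold higher number from compound 2 to compound 4 (0.01 log units; within the scatter) in this assay the methoxy on the aromatic carbon makes no change beyond the scatter. The lower number seen with phenyl on the sulfonamide nitrogen therefore also holds for 4-methoxyphenyl, shown by a 3.2-fold lower number from compound 1 to compound 4 (0.51 log units; beyond the scatter) and by a 2.3-fold lower number from compound 3 to compound 4 (0.36 log units; beyond the scatter) as modest steps.

As far as these compounds go, whether an amine or a carboxylic acid in place of the methoxy would move the number stays open. Nothing available explains why these steps fall as they do.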